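The compounds below may be only part of what the source reports. "The series", "measured", "known", "first", "only" and "open" are said of these compounds alone.

Of the compounds shown here, three sharing one core have been measured in a functional assay on Mahlavu cells (Homo sapiens) for antiproliferative activity, read by sulforhodamine B assay, with a stated time of 72 h; on this read-out higher numbers stand for weaker inhibition and lower numbers for stronger inhibition. Compound 1 `FC(F)(F)c1ccc(CN2CCN(Cc3cc(-c4ccc(OCc5ccccc5)cc4)on3)CC2)cc1` gives 11700 nM. Compound 2 `Fc1cccc(COc2ccc(-c3cc(CN4CCN(Cc5ccc(C(F)(F)F)cc5)CC4)no3)cc2)c1` gives 2900 nM, and compound 3 `COc1ccccc1COc1ccc(-c2cc(CN3CCN(Cc4ccc(C(F)(F)F)cc4)CC3)no2)cc1` gives 3900 nM. Compound 3 thus stands second highest of the three, close to compound 2 and well apart from compound 1: the step of a 3.0-fold lower number from compound 1 to compound 3 (0.48 log units; beyond the scatter) is a modest gain, while a 1.3-fold higher number from compound 2 to compound 3 (0.13 log units; within the scatter) lies within the scatter.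

Compound 4 `COc1cccc(COc2ccc(-c3cc(CN4CCN(Cc5ccc(C(F)(F)F)cc5)CC4)no3)cc2)c1` is the next step. It differs from compound 3 only in where the methoxy group sits on the benzyl ring: 3-methoxyphenyl in place of 2-methoxyphenyl on a saturated chain carbon bound to an oxygen on an aromatic ring. Within the data shown here, no measured pair shows exactly this move. The nearest evidence is indirect: adding fluoro or methoxy to that ring gave a 4.0-fold lower number from compound 1 to compound 2 (0.61 log units; beyond the scatter) and a 3.0-fold lower number from compound 1 to compound 3 (0.48 log units; beyond the scatter), and exchanging one substituted ring for another gave a 1.3-fold higher number from compound 2 to compound 3 (0.13 log units; within the scatter). The step of a 1.2-fold lower number from compound 3 to compound 4 (0.07 log units; within the scatter) is therefore expected to stay within the scatter. Compound 4 is estimated at 3300 nM, within a range of 1500 nM to 7000 nM.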

Compound 4, half-maximal inhibitory concentration: 1400 nM
Estimate against measurement, compound 4: 2.4-fold (0.37 log units) above; the measured number lies below the stated range.
By their numbers in this assay, from the lowest: compound 4; then compounds 2 and 3 (each within the scatter of the next); then compound 1.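

Moving the methoxy group alone, with the same atoms joined differently, changes the outcome in this assay: a 2.8-fold lower number from compound 3 to compound 4 (0.44 log units; beyond the scatter) is a step beyond the scatter, so where the group sits on this ring matters, and not only whether a group is there. The 3-methoxyphenyl ring also separates from the 3-fluorophenyl ring, with a 2.1-fold lower number from compound 2 to compound 4 (0.32 log units; beyond the scatter), whereas the 2-methoxyphenyl ring did not, and an 8.4-fold lower number from compound 1 to compound 4 (0.92 log units; beyond the scatter) is the largest step seen so far against the plain benzyl ring of compound 1. No measurement offered here accounts for this difference between the two methoxy positions.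

The compounds shown leave open whether a hydroxyl, a nitrile or an amine at this place on the ring would match the methoxy group. They also leave open whether moving the fluoro group would matter as much.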